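The source may report more compounds than this note shows. Statements on the series, on what has been measured and on what is new or still open speak of the compounds shown alone.

Of the compounds shown here, two have been measured so far in a functional assay on MCF7 cells (Homo sapiens) for cytotoxicity, read by MTT assay, with a stated time of 48 h; a lower number here means a stronger inhibitor, a higher number a weaker inhibitor. Compound 2 `Cc1ccc(S(=O)(=O)/N=C(/CCNC2=CC(=O)c3ccccc3C2=O)NC(C)C)cc1` gives 16500 nM, and compound 1 `COc1ccc(N/C(CCNC2=CC(=O)c3ccccc3C2=O)=N\S(=O)(=O)c2ccc(C)cc2)cc1OC` gives 12300 nM; the step of a 1.3-fold higher number from compound 1 to compound 2 (0.13 log units; within the scatter) lies within the scatter, so neither compound stands apart from the other, and compound 2 simply sits at one end of a pair that cannot be told apart.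

Compound 3 `Cc1ccc(S(=O)(=O)/N=C(/CCNC2=CC(=O)c3ccccc3C2=O)NCc2ccccc2)cc1` differs from compound 2 in one place: benzyl in place of isopropyl on an amine nitrogen. For the measured compounds named here, the only measured step that bears on this position is a 1.3-fold higher number from compound 1 to compound 2 (0.13 log units; within the scatter), which swapped a larger aromatic group for isopropyl on the same amine nitrogen without moving beyond the scatter. Putting a benzyl group there in place of isopropyl is therefore expected to change little, so the expected step is a 1.2-fold lower number from compound 2 to compound 3 (0.07 log units; within the scatter). Compound 3 is estimated at 14000 nM, with a range from 6000 nM to 35000 nM.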

Compound 3, half-maximal inhibitory concentration: 3630 nM
Compound 3: the middle estimate sits 3.9-fold (0.59 log units) above what was measured, outside the stated range (below it).
By their numbers in this assay, from the lowest: compound 3; then compounds 1 and 2 (each within the scatter of the next).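

On this amine nitrogen, the group does make a difference in this assay: benzyl in place of isopropyl gives a 4.5-fold lower number from compound 2 to compound 3 (0.66 log units; beyond the scatter) and so moves beyond the scatter, which the earlier pair gave no sign of. Benzyl in place of 3,4-dimethoxyphenyl gives a 3.4-fold lower number from compound 1 to compound 3 (0.53 log units; beyond the scatter) as well, so carrying an aromatic ring is not enough in itself, since compound 1 has such a ring and still cannot be told apart from compound 2, which has none. Nothing available here explains why benzyl gives the lowest number of the three.

On these data alone, it remains open whether this gain belongs to benzyl alone or extends to related groups. Phenethyl, cyclohexylmethyl or a benzyl group carrying a chlorine atom would each help to show how far it reaches.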